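A few compounds are considered here, and "the series" means these few. Any claim that something is new, unique, unknown or untested is made for them only; others in the source may bear on it.

Compound 2 `O=C1CC(c2ccccc2F)C(=O)N1CN1CCN(c2cccc(C(F)(F)F)c2)CC1` reaches its effect in a functional assay on the whole organism (strain CF-1 albino) with Mus musculus as the target, with a stated time of 4 h (a lower number here means that less compound is needed, a higher number that more compound is needed for the effect), at 100 mg/kg. Compound 1 `O=C1CC(c2ccccc2F)C(=O)N1CN1CCN(c2ccccc2)CC1` shares the same core and gives 300 mg/kg in this assay. Going by the values given here, of these two numbers compound 2 stands lowest, and the only other compound, compound 1, lies one step away: a 3.0-fold lower number from compound 1 to compound 2 (0.48 log units; beyond the scatter). Compound 3 `O=C1CC(c2ccccc2F)C(=O)N1CN1CCN(c2ncccn2)CC1` carries a single change from compound 2: pyrimidin-2-yl in place of 3-(trifluoromethyl)phenyl on an amine nitrogen in a ring. Among the compounds with values here, the one measured step bears on this only in part: it showed that trifluoromethyl in place of hydrogen on an aromatic carbon lowered the number, so removing that group again may undo the gain, while the pyrimidin-2-yl that enters has no measured counterpart here. Compound 3 is therefore expected to need more compound than compound 2, as a 3.0-fold higher number from compound 2 to compound 3 (0.48 log units; beyond the scatter). The estimate for compound 3 is 300 mg/kg, within a range from 100 mg/kg to 1000 mg/kg.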

Compound 3, minimum effective dose: 100 mg/kg
Compound 3: middle estimate off by 3.0-fold (0.48 log units), on the high side; the measured number falls inside the stated range.
By their numbers in this assay, from the lowest: compounds 2 and 3 (each within the scatter of the next); then compound 1.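

At this position, on an amine nitrogen in a ring, a carbon-only aromatic ring bearing trifluoromethyl and a ring with two nitrogens give matching results in this assay with no change at the digits printed from compound 2 to compound 3 (within the scatter) in the minimum effective dose. The trifluoromethyl group is therefore not needed to get past the plain phenyl of compound 1, as pyrimidin-2-yl in place of that phenyl gives a 3.0-fold lower number from compound 1 to compound 3 (0.48 log units; beyond the scatter) on its own. Nothing measured here explains why two such different groups end up level.

Still open, going by these compounds, is whether a pyridin-2-yl or a plain methyl on that same amine nitrogen would keep the dose of compound 3 in this assay or lose it. A chlorine or a methoxy group in place of the trifluoromethyl of compound 2 also remains untested among the compounds shown here.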